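The source may hold more compounds than are shown below. What is called first, only, known or untested is meant among the compounds shown, and "the series" means these compounds.

Compound 1, `CC(=O)Oc1ccc(-c2ccc(F)cc2F)cc1C(=O)Nc1ccccc1C`, in a functional assay on the whole organism (strain Kunming) for inhibition, with Mus musculus as the target, in the writhing test, at a dose of 40 mg/kg by the oral route (a lower number here means less inhibition, a higher number more inhibition at the dose given (going by the name of the read-out)), gives 12.3%.
Compound 2, `CC(=O)Oc1ccc(-c2ccc(F)cc2F)cc1C(=O)Nc1cccc(C)c1`, in this assay gives 19%.

Among the measured compounds shown here, of the two numbers, compound 2 has the higher one, but the only measured step, a number 6.7 percentage points higher from compound 1 to compound 2 (within the scatter), lies within the scatter, so the two compounds cannot be told apart on these data.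

Compound 3, `CC(=O)Oc1ccc(-c2ccc(F)cc2F)cc1C(=O)Nc1ccc(Cl)cc1`, is the next compound. It differs from compound 2 by 4-chlorophenyl in place of 3-methylphenyl on an amide-type nitrogen. For the measured compounds named here, the one measured step bears on it only loosely: it also changed the aryl group on the amide-type nitrogen, and it stayed within the scatter. No measured step exchanges a methyl group for a chlorine atom, so nothing shown points to a move in either direction.

Compound 3 is therefore expected to give a step of a number 1 percentage points lower from compound 2 to compound 3 (within the scatter), within the scatter. The estimate for compound 3 is 18%, with a range from 5% to 35%.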

Compound 3, a percentage reported as inhibition, in the whole organism at one dose (the size of the read-out at that dose, not a potency): 29.9%
Compound 3: middle estimate off by 11.9 percentage points, on the low side; the measured number falls inside the stated range.
By their numbers in this assay, from the lowest: compounds 1 and 2 (each within the scatter of the next); then compound 3.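

In this assay, the aryl group on the amide-type nitrogen now proves able to move the read-out: 4-chlorophenyl in place of 3-methylphenyl gives a number 10.9 percentage points higher from compound 2 to compound 3 (beyond the scatter), and 4-chlorophenyl in place of 2-methylphenyl gives a number 17.6 percentage points higher from compound 1 to compound 3 (beyond the scatter). Among the compounds shown here, the position therefore responds to a change of aryl group, which the single earlier step between the two methylphenyl compounds, lying within the scatter, could not show. No measurement at hand accounts for this gain in the read-out.

The compounds shown leave open whether the chlorine atom itself or its place on the ring carries the step, as neither 4-methylphenyl nor 3-chlorophenyl stands among them. Also open, going by these compounds, is how an unsubstituted phenyl, or a phenyl bearing an amine or a carboxylic acid, would read out at this dose.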